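A few compounds are considered here, and "the series" means these few. Any claim that something is new, unique, unknown or untested is made for them only; others in the source may bear on it.

Of the compounds shown here, two sharing one cysteine-derived core have been tested so far in a functional assay on UACC-62 cells (Homo sapiens) for cytotoxicity, read by MTT assay, with a stated time of 6 days; on this read-out lower numbers stand for stronger inhibition and higher numbers for weaker inhibition. Among the measured compounds shown here, compound 1 `CC(=O)N[C@@H](CSC(=O)Nc1ccc(I)cc1)C(=O)O` gives 46200 nM in this assay, and this is the only real number in the set. Compound 2 `COc1ccccc1CNC(=O)SC[C@H](NC(C)=O)C(=O)O` is reported as > 200000 nM in this assay, which is a boundary of the test rather than a measured number, as noted in the limit of > 200000 nM in this assay, at which 1 of the 2 values shown sits. For the measured compounds named here, compound 1 therefore stands alone as the one compound with a measured value, and no step between two measured compounds is available to guide expectations.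

Compound 3 `CC(=O)N[C@@H](CSC(=O)Nc1ccc(F)cc1)C(=O)O` has not yet been measured. It differs from compound 1 in one place: fluoro in place of iodo on an aromatic carbon. Going by the values given here, no measured pair shows what this swap does here, so its size and direction are uncertain. The expectation is that the step from compound 1 to compound 3, a 2.4-fold higher number from compound 1 to compound 3 (0.38 log units; beyond the scatter), points toward weaker inhibition, probably somewhat beyond the usual scatter. Compound 3 is estimated at 110000 nM, with a range from 40000 nM to 300000 nM.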

Compound 3, half-maximal inhibitory concentration: 36 nM
Compound 3: middle estimate off by 3100-fold (3.49 log units), on the high side; measured number below the stated range.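

In this assay, the aromatic carbon para to a large group proves to be a highly sensitive place: exchanging one atom there, fluoro in place of iodo, gives a 1300-fold lower number from compound 1 to compound 3 (3.11 log units; beyond the scatter). Among the compounds shown here, until now the set held no step at all, so nothing showed that this position could matter; this pair shows that the choice of this one substituent can separate weak from very strong inhibition while the shared core stays the same. The exchange leaves the counts of heavy atoms and hydrogen-bond donors and acceptors unchanged and adds no net charge, and nothing measured here accounts for the size of the step.

Chloro and bromo at the same place would show whether the number falls gradually on going from iodo to fluoro or whether fluoro alone stands apart, and a plain hydrogen there would show whether a halogen is needed at all. Compound 2 sits at a limit of the assay, > 200000 nM, and differs from compound 1 in more than one place, so it leaves these questions open.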